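Removing One Fluorine From a Poorly Soluble Amide

A few compounds are considered here, and "the series" means these few. Any claim that something is new, unique, unknown or untested is made for them only; others in the source may bear on it.

Compound 1 `NC(=O)c1cccn2cc(-c3cccc(-c4cccc(F)c4)c3)nc12` and compound 2 `NC(=O)c1cccn2cc(-c3cccc(-c4cncc(OCC(F)F)c4)c3)nc12` share one core and were tested in a physicochemical assay for solubility, in phosphate buffer, with a stated time of 24 h, at pH 7.4; on this read-out lower numbers stand for lower solubility and higher numbers for higher solubility. In this assay compound 1 gives only a limit of the assay, < 1000 nM. Compound 2 likewise gives only a limit in this assay, < 1000 nM. Both values sit at the limit of < 1000 nM in this assay, at which 2 of the 2 values shown sit, and compound 2 stands at that limit rather than at a number. Compound 3 `NC(=O)c1cccn2cc(-c3cccc(-c4cncc(OCCF)c4)c3)nc12` differs from compound 2 by hydrogen in place of fluoro on a saturated chain carbon bound to a fluorine atom and a saturated chain carbon. Going by the values given here, no measured step shows what this change does, so the expected step from compound 2 to compound 3, a step that the limit leaves unreadable from compound 2 to compound 3, is none beyond the scatter. Compound 3 is thus expected to give 800 nM in this assay, within 250 nM to 3000 nM.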

Compound 3, solubility: 16000 nM
Compound 3: the middle estimate sits 20-fold (1.30 log units) below what was measured; the measured number lies above the stated range.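

In this assay, changing 2,2-difluoroethoxy to 2-fluoroethoxy gives an at least 16-fold higher number from compound 2 to compound 3 (1.20 log units; beyond the scatter), a large step from the loss of a single fluorine atom. At this saturated chain carbon, then, one atom separates a compound with a readable number from one without. The true size of the step stays unknown, as compound 2 gives only a limit of the assay: the limit of < 1000 nM in this assay, at which 2 of the 3 values shown sit.

On these data alone, what an ethoxy group carrying no fluorine, or an amine on the same chain, would give here stays open. The reason for the step also remains unexplained.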